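Catechol sulfone amides: fluoro to nitro on the benzamide ring

A few compounds are considered here, and "the series" means these few. Any claim that something is new, unique, unknown or untested is made for them only; others in the source may bear on it.

Compound 1 `CC(=O)Oc1ccc(/C=C/S(=O)(=O)CCc2ccc(NC(=O)c3ccc(F)cc3)cc2)cc1OC(C)=O` gives 162000 nM in an ADME assay on TZM cells (Homo sapiens) for cytotoxicity, read by CCK-8 assay, with a stated time of 2 days; a lower number here means that less compound is tolerated, a higher number that more compound is tolerated. Compound 2 `CC(=O)Oc1ccc(/C=C/S(=O)(=O)CCc2ccc(NC(=O)c3cc(F)cc(F)c3)cc2)cc1OC(C)=O` gives 225000 nM in this assay, and the change from a 1.4-fold higher number from compound 1 to compound 2 (0.14 log units; within the scatter). Compound 3 `O=C(Nc1ccc(CCS(=O)(=O)/C=C/c2ccc(O)c(O)c2)cc1)c1ccc(F)cc1` returns only a limit of the assay in this assay, namely > 1000000 nM. Compound 3 therefore stands at the limit of > 1000000 nM in this assay, at which 1 of the 3 values shown sits, without a number of its own. Compound 4 `O=C(Nc1ccc(CCS(=O)(=O)/C=C/c2ccc(O)c(O)c2)cc1)c1ccc([N+](=O)[O-])cc1` differs from compound 3 by nitro in place of fluoro on an aromatic carbon. Among the compounds with values here, the only measured step concerns a different change on the same carbonyl-bearing ring, in the diacetylated pair, and lies within the scatter, so it bears only loosely on this exchange. No step beyond the scatter is expected in this assay, and a limit again seems most likely. Compound 4 is expected at 1000000 nM, within 300000 nM to 3000000 nM. The expected step is a number no higher from compound 3 to compound 4 (the limit leaves the size open).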

Compound 4, half-maximal cytotoxic concentration: 483000 nM
Compound 4: middle estimate off by 2.1-fold (0.32 log units), on the high side, and the stated range covers the measured number.
By their numbers in this assay, from the lowest: compounds 1 and 2 (each within the scatter of the next); then compound 4. At a limit, above all of these: compound 3.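

Nitro in place of fluoro on this aromatic carbon shifts the read-out in this assay, with an at least 2.0-fold lower number from compound 3 to compound 4 (0.31 log units; beyond the scatter). The earlier step on the same ring, a 1.4-fold higher number from compound 1 to compound 2 (0.14 log units; within the scatter), gave no change beyond the scatter, so this is the first exchange on that ring shown to exceed it. The value of compound 3 is a limit, not a number: the limit of > 1000000 nM in this assay, at which 1 of the 4 values shown sits.

On these data alone, whether an amine or a carboxylic acid at this position would give a similar shift remains open. So does whether nitro would have any such effect in the diacetylated compounds.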